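Aromatic hydroxy added to compound 3 in cytotoxicity series

The source may hold more compounds than are shown below. What is called first, only, known or untested is meant among the compounds shown, and "the series" means these compounds.

Compound 1, `COc1cc2c(cc1O)O[C@H](c1ccccc1)CC2=O`: 5900 nM
Compound 2, `O=C1c2ccc(O)cc2O[C@H](c2ccccc2)[C@H]1O`: > 100000 nM (a limit of the assay, not a number)
Compound 3, `COc1cc2c(cc1O)O[C@H](c1ccccc1)[C@@H](O)C2=O`: > 100000 nM (a limit of the assay, not a number)

Among the compounds with values here, in a functional assay on cells (Mus musculus) for cytotoxicity, read by MTT assay, with a stated time of 72 h (on this read-out lower numbers stand for stronger inhibition and higher numbers for weaker inhibition), compound 1 is the only member with a numeric value. Compound 3 sits at the assay limit, as does compound 2 (the limit of > 100000 nM in this assay, at which 2 of the 3 values shown sit). Within the data shown here, the step of an at least 16-fold higher number from compound 1 to compound 3 (1.22 log units; beyond the scatter) is the one readable change; the step that the two limits leave unreadable from compound 2 to compound 3 cannot be sized.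

Compound 4, `COc1c(O)cc2c(c1O)C(=O)[C@H](O)[C@@H](c1ccccc1)O2`, differs from compound 3 by hydroxy in place of hydrogen on an aromatic carbon. Among the measured compounds shown here, no measured step concerns a hydroxy on an aromatic carbon; the one sized step involved a hydroxy on a saturated ring carbon and the other a methoxy, so neither bears directly on this change. With compound 3 already at the limit, no readable step is expected in this assay; the estimated step that the limit leaves unreadable from compound 3 to compound 4 is none beyond the scatter. Compound 4 is therefore expected near 150000 nM, most likely reported again as a limit, within 60000 nM to 400000 nM.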

Compound 4, half-maximal inhibitory concentration: > 100000 nM
Compound 4 was reported as a limit; the forecaster's own chance of this, stated with the estimate: 75%; the middle value does not contradict the limit.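

Compound 4, like compound 3, is reported only as a limit in this assay, so no step between them can be read: the limit of > 100000 nM in this assay, at which 3 of the 4 values shown sit.

The compounds shown leave open whether hydroxy in place of hydrogen on an aromatic carbon changes the read-out in this assay at all.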